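Replacing Carbamoyl with Isopropyl: What to Expect

The source may report more compounds than this note shows. Statements on the series, on what has been measured and on what is new or still open speak of the compounds shown alone.

Of the compounds shown here, three have so far been tested in a functional assay on the whole organism (Tail, strain ICR) with Mus musculus as the target, in the tail flick test, with a stated time of 60 min, at a dose of 25 umol/kg by the oral route; on this read-out higher numbers stand for a stronger effect at the one dose given and lower numbers for a weaker effect. Compound 1 `NC(=O)C[C@H](NC(=O)CN(c1nc(Cl)nc2[nH]cnc12)C1CC1)C(=O)O` gives 43.1%. Compound 2 `CSCC[C@H](NC(=O)CN(c1nc(Cl)nc2[nH]cnc12)C1CC1)C(=O)OCc1ccccc1` gives 30.8%, and compound 3 `CSCC[C@H](NC(=O)CN(c1ncnc2c1ncn2C1CCCCO1)C1CC1)C(=O)OCc1ccccc1` gives 41%. Of these three numbers, that of compound 1 is the highest, but its gap to compound 3 lies within the usual scatter, so the two cannot be told apart; its gap to compound 2 lies beyond the scatter, so compound 1 stands clearly above compound 2 in this assay.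

Compound 4 `CC(C)C[C@H](NC(=O)CN(c1nc(Cl)nc2[nH]cnc12)C1CC1)C(=O)O` has not yet been measured. It differs from compound 1 in a single place: isopropyl in place of carbamoyl on a saturated chain carbon, two bonds along the chain from an amide-type nitrogen and a carbonyl carbon. Among the compounds with values here, no measured pair shows what this particular swap does, and no other step between measured compounds is available as a guide. The step of a number 3.1 percentage points lower from compound 1 to compound 4 (within the scatter) is therefore expected to be small, most likely within the scatter, with a wide uncertainty in either direction. On that basis compound 4 is expected to give about 40% in this assay, within a range from 20% to 60%.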

Compound 4, a percentage reported as activity, at one dose (the size of the read-out at that dose, not a potency): 36.4%
For compound 4 the middle estimate is 3.6 percentage points above the measured one; the measured number falls inside the stated range.
By their numbers in this assay, from the lowest: compounds 2, 4, 3 and 1 (each within the scatter of the next, the first and the last beyond it).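

In this assay, within the data shown here, putting isopropyl in place of carbamoyl on this saturated chain carbon gives a number 6.7 percentage points lower from compound 1 to compound 4 (within the scatter), the only measured step at this position, so the two compounds cannot be told apart at this dose. Carbamoyl carries a hydrogen-bond donor and a hydrogen-bond acceptor and isopropyl carries neither, yet this exchange does not separate the two read-outs beyond the usual scatter. Nothing available explains this result.

The compounds shown leave open whether an amine or a phenyl group at the same place would also read like carbamoyl and isopropyl, or would stand apart from them. They also leave open whether compound 1 and compound 4 would stay together at other doses, since a single dose gives the size of an effect and not a potency.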